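The compounds below may be only part of what the source reports. "The series", "measured", "known", "first", "only" and "open" are said of these compounds alone.

Measured so far in a functional assay on A549 cells (Homo sapiens) for antiproliferative activity, read by MTT assay, with a stated time of 48 h; on this read-out higher numbers stand for weaker inhibition and lower numbers for stronger inhibition:
Compound 1 `COc1cc(-c2nnc3c(OC4COC4)cc(-c4ccc5c(ccn5C)c4)cn23)cc(OC)c1OC`: 516 nM
Compound 2 `COc1cc(-c2nnc3c(OCC(F)(F)F)cc(-c4ccc5c(ccn5C)c4)cn23)cc(OC)c1OC`: 614 nM

Level with compound 1 within the scatter, compound 2 stands at 614 nM in this assay. Compound 3 `COc1cc(-c2nnc3c(OC4CCC4)cc(-c4ccc5c(ccn5C)c4)cn23)cc(OC)c1OC` differs from it as follows: cyclobutyl in place of 2,2,2-trifluoroethyl on an oxygen on an aromatic ring. Among the compounds with values here, the only measured change on this oxygen, 2,2,2-trifluoroethyl in place of oxetan-3-yl, gave a 1.2-fold higher number from compound 1 to compound 2 (0.08 log units; within the scatter). Within the data shown here, no measured step covers cyclobutyl itself, so no shift beyond the scatter is expected, in either direction. The expected change is a 1.1-fold lower number from compound 2 to compound 3 (0.05 log units; within the scatter). For compound 3 the estimated value is 550 nM, with an expected range of 250 nM to 1200 nM.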

Compound 3, half-maximal inhibitory concentration: 176 nM
The estimate for compound 3 lay 3.1-fold (0.49 log units) above the measured number, and the stated range ends above it.
By their numbers in this assay, from the lowest: compound 3; then compounds 1 and 2 (each within the scatter of the next).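

In this assay, the group on this oxygen now makes a difference: cyclobutyl gives a 3.5-fold lower number from compound 2 to compound 3 (0.54 log units; beyond the scatter) and also a 2.9-fold lower number from compound 1 to compound 3 (0.47 log units; beyond the scatter) in the comparison with oxetan-3-yl, whereas the two earlier groups could not be told apart. A ring on this oxygen is not enough in itself, since compound 1 also carries one and stays level with compound 2. Nothing available here accounts for the step.

What the compounds shown leave open is whether this gain depends on ring size or on an all-carbon group at all. Cyclopropyl, cyclopentyl or a chain ending in an amine on this oxygen could still fall on either side of compound 3.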